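This account rests on a few compounds, and the source may have more. Where it says the series, first, only, none or still open, it means among the compounds named here.

Compound 1 `Cc1nc(N2CCN(C)CC2)c2nc(-c3cccc(C(F)(F)F)c3)n(C3CCOCC3)c2n1` gives 44%
Compound 2 `COc1ccccc1-c1nc2c(N3CCN(C)CC3)nc(C)nc2n1C1CCOCC1` gives 36%

In an ADME assay (liver) for metabolic stability, with Liver microsome (Canis lupus familiaris) as the target, read by LC-MS, using microsomes, with a stated time of 30 min, tested at 4 uM (on this read-out lower numbers stand for a less stable compound and higher numbers for a more stable compound), compound 2 at 36% lies within the scatter of compound 1. Compound 3 `COc1cccc(-c2nc3c(N4CCN(C)CC4)nc(C)nc3n2C2CCOCC2)c1` differs from compound 2 by one change: 3-methoxyphenyl in place of 2-methoxyphenyl on an aromatic carbon with 3-methoxyphenyl in place of 2-methoxyphenyl on an aromatic carbon. For the measured compounds named here, the one measured step that bears on this is a number 8 percentage points lower from compound 1 to compound 2 (within the scatter) and it also exchanged the group on that aromatic carbon. No step beyond the scatter is therefore expected, and the estimate of a number 4 percentage points higher from compound 2 to compound 3 (within the scatter) carries no firm direction. Compound 3 is expected to give 40% with 25% to 55% as the estimated range.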

Compound 3, percent of the compound remaining: 46%
For compound 3 the middle estimate is 6 percentage points below the measured one; the range from low to high includes it.
By their numbers in this assay, from the lowest: compounds 2, 1 and 3 (each within the scatter of the next).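

Across the shared core in this assay, 3-methoxyphenyl in place of 2-methoxyphenyl gives a number 10 percentage points higher from compound 2 to compound 3 (within the scatter) and stays within the scatter. Methoxy in place of trifluoromethyl gives a number 2 percentage points higher from compound 1 to compound 3 (within the scatter) and also stays within the scatter, so none of the three substituted phenyl groups on this carbon, next to the ring atom bearing the oxan-4-yl group, can be separated from the others on this read-out. Nothing available accounts for these numbers. The compounds shown leave open whether a carboxylic acid or a morpholine on the phenyl ring, or a pyridine in its place, would give a step beyond the scatter.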